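From Dimethoxyphenyl to Hydroxymethylphenyl on a Shared Core

The source may hold more compounds than are shown below. What is called first, only, known or untested is meant among the compounds shown, and "the series" means these compounds.

compound 1: `COc1cccc(CNc2ncnc3c2ncn3[C@@H]2O[C@H](CO)[C@@H](O)[C@H]2O)c1OC` — "not determined" (no result reported)
compound 2: `OC[C@H]1O[C@@H](n2cnc3c(NCc4cc(F)cc(F)c4)ncnc32)C(O)C1O` — > 166000 nM
compound 3: `Cc1ccc(O)c(CNc2ncnc3c2ncn3[C@@H]2O[C@H](CO)[C@@H](O)[C@H]2O)c1` — to be measured

The work rests on a functional assay on G-361 cells (Homo sapiens) for antiproliferative activity, with a stated time of 72 h; on this read-out higher numbers stand for weaker inhibition and lower numbers for stronger inhibition. In this assay compound 1 gives "not determined" (no result reported), so no single number places it among the others. In this assay compound 2 gives > 166000 nM, which is a limit of the assay and not a number. Among the measured compounds shown here, the only evidence on potency is therefore (the limit of > 166000 nM in this assay, at which 1 of the 2 values shown sits), and compound 1 itself stands nowhere on the numbers, since its result was not reported.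

Compound 3 differs from compound 1 in one place: 2-hydroxy-5-methylphenyl in place of 2,3-dimethoxyphenyl on a saturated chain carbon bound to a nitrogen on an aromatic ring. For the measured compounds named here, no step between two measured compounds is available, so the size of the change from compound 1 to compound 3 in this assay cannot be read from any measured pair. With compound 1 unplaced and compound 2 sitting at a limit, the expectation is that the change brings nothing beyond the scatter and that compound 3 remains weak. Compound 3 is therefore estimated at 100000 nM in this assay, with an expected range from 20000 nM to 300000 nM, and a real chance that only a limit is reported.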

Compound 3, half-maximal inhibitory concentration: > 166000 nM
Compound 3 gave a limit, no number; the forecaster's own chance of this, stated with the estimate: 60%; middle value at least 1.6-fold (0.22 log units) from the limit.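

In this assay compound 3 gives > 166000 nM, which is a limit of the assay and not a number. Among the compounds shown here, compound 1 has no single number either, and no step between compound 1 and compound 3 can be read. The compounds shown leave open what exchanging 2,3-dimethoxyphenyl for 2-hydroxy-5-methylphenyl does to potency, as the evidence stops at a limit: the limit of > 166000 nM in this assay, at which 2 of the 3 values shown sit.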